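A second methoxy on the phenyl group of compound 3

A few compounds are considered here, and "the series" means these few. Any claim that something is new, unique, unknown or untested is made for them only; others in the source may bear on it.

Measured so far in a functional assay on MCF7 cells (Homo sapiens) for inhibition, read by MTT assay, with a stated time of 48 h; on this read-out higher numbers stand for weaker inhibition and lower numbers for stronger inhibition:
compound 1 `c1ccc(C(c2c[nH]c3ccccc23)c2c[nH]c3ccccc23)cc1` gives 22200 nM
compound 2 `Brc1ccc2[nH]cc(C(c3ccccc3)c3c[nH]c4ccc(Br)cc34)c2c1` gives 5500 nM
compound 3 `COc1ccc(C(c2c[nH]c3ccc(Br)cc23)c2c[nH]c3ccc(Br)cc23)cc1` gives 2300 nM

Compound 3 holds the lowest of the three numbers; compound 2 is nearest to it and compound 1 furthest, both steps beyond the scatter. Among the compounds with values here, compound 1 and compound 2 differ by more than one change, so only their two values are noted, with no single step drawn between them.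

The next compound, compound 4 `COc1ccc(C(c2c[nH]c3ccc(Br)cc23)c2c[nH]c3ccc(Br)cc23)cc1OC`, differs from compound 3 in one place: methoxy in place of hydrogen on an aromatic carbon. Cut one bond further out, the change reads 4-methoxyphenyl to 3,4-dimethoxyphenyl.

Within the data shown here, one measured step bears on it directly: a 2.4-fold lower number from compound 2 to compound 3 (0.38 log units; beyond the scatter), which is the same kind of change, a first methoxy entering on the same phenyl group. Whether a second methoxy entering on that group repeats the step is not shown by any measured pair here. The expectation is therefore a small step in the same direction, or none beyond the scatter, rather than a second step of the same size.

Compound 4 is expected to give about 1500 nM in this assay, between 600 nM and 4500 nM. The expected step is a 1.5-fold lower number from compound 3 to compound 4 (0.19 log units; within the scatter).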

Compound 4, half-maximal inhibitory concentration: 7800 nM
For compound 4 the middle estimate is 5.2-fold (0.72 log units) below the measured one; the whole stated range lies below it.
By their numbers in this assay, from the lowest: compound 3; then compounds 2 and 4 (each within the scatter of the next); then compound 1.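

In this assay the two methoxy steps on this phenyl group do not add up: a 2.4-fold lower number from compound 2 to compound 3 (0.38 log units; beyond the scatter) for the first methoxy stands against a 3.4-fold higher number from compound 3 to compound 4 (0.53 log units; beyond the scatter) for the second, which enters ortho to a methoxy group and meta to a large group. Taken from the plain phenyl group, the change to 3,4-dimethoxyphenyl gives a 1.4-fold higher number from compound 2 to compound 4 (0.15 log units; within the scatter) and so does not carry over the lower number reached with 4-methoxyphenyl. The same replacement, methoxy in place of hydrogen on an aromatic carbon, thus moves the number in opposite directions on one phenyl group, and in this series the name of the change alone does not fix its direction.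

Still open, from the compounds shown here alone, is whether the higher number belongs to a methoxy at this place on its own or to the two methoxy groups together, and how a hydroxy group, a fluorine atom or an amine would read at the same place. Nothing available here accounts for the reversal.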